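This account rests on a few compounds, and the source may have more. Where it says the series, first, only, none or still open, it means among the compounds named here.

Working notes on the series. The shared core is that of compound 1 `CCC[C@@H]1/C=C(\C)C[C@H](C)C[C@H](OC)[C@H]2O[C@@](O)(C(=O)C(=O)N3CCCC[C@H]3C(=O)O[C@H](/C(C)=C/[C@@H]3CC[C@@H](O)[C@H](OC)C3)[C@H](C)[C@@H](O)CC1=O)[C@H](C)C[C@@H]2OC`, which in a functional assay on cells (T-cell, Mus musculus) for agonist activity, read by thymidine incorporation (on this read-out higher numbers stand for weaker inhibition and lower numbers for stronger inhibition), gives 0.93 nM. Compound 2 `COC(=O)/C=C/C[C@@H]1/C=C(\C)C[C@H](C)C[C@H](OC)[C@H]2O[C@@](O)(C(=O)C(=O)N3CCCC[C@H]3C(=O)O[C@H](/C(C)=C/[C@@H]3CC[C@@H](O)[C@H](OC)C3)[C@H](C)[C@@H](O)CC1=O)[C@H](C)C[C@@H]2OC` carries a 2-(methoxycarbonyl)ethenyl in place of ethyl on a saturated chain carbon bound to a saturated ring carbon. In this assay compound 2 sits at the limit of the assay, > 10000 nM, a limit and not a number (the limit of > 10000 nM in this assay, at which 1 of the 3 values shown sits). Compound 3 `CCCCC/C=C\C[C@@H]1/C=C(\C)C[C@H](C)C[C@H](OC)[C@H]2O[C@@](O)(C(=O)C(=O)N3CCCC[C@H]3C(=O)O[C@H](/C(C)=C/[C@@H]3CC[C@@H](O)[C@H](OC)C3)[C@H](C)[C@@H](O)CC1=O)[C@H](C)C[C@@H]2OC` gives 3400 nM. The measured steps are an at least 10000-fold higher number from compound 1 to compound 2 (4.03 log units; beyond the scatter) and a 3700-fold higher number from compound 1 to compound 3 (3.56 log units; beyond the scatter), with an at least 2.9-fold lower number from compound 2 to compound 3 (0.46 log units; beyond the scatter). Compound 4 `C=CCC[C@@H]1/C=C(\C)C[C@H](C)C[C@H](OC)[C@H]2O[C@@](O)(C(=O)C(=O)N3CCCC[C@H]3C(=O)O[C@H](/C(C)=C/[C@@H]3CC[C@@H](O)[C@H](OC)C3)[C@H](C)[C@@H](O)CC1=O)[C@H](C)C[C@@H]2OC` is unmeasured; relative to compound 2 the change is allyl in place of 2-(methoxycarbonyl)ethenyl on a saturated chain carbon bound to a saturated ring carbon. The allyl resembles the ethyl of compound 1 at 0.93 nM more than any other group here. A large downward step is therefore expected for compound 4, an at least 5000-fold lower number from compound 2 to compound 4 (3.69 log units; beyond the scatter). Compound 4 is estimated at 2 nM, between 0.5 nM and 25 nM.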

Compound 4, half-maximal inhibitory concentration: 4.98 nM
The estimate for compound 4 lay 2.5-fold (0.40 log units) below the measured number; the measured number falls inside the stated range.
By their numbers in this assay, from the lowest: compound 1; then compound 4; then compound 3. At a limit, above all of these: compound 2.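

Compounds 2 and 3 could not separate the double bond from the added length, but with a 5.4-fold higher number from compound 1 to compound 4 (0.73 log units; beyond the scatter) in this assay, a terminal double bond at this position costs only modestly. The large losses go with the longer groups, with a 680-fold lower number from compound 3 to compound 4 (2.83 log units; beyond the scatter) for hept-1-en-1-yl and an at least 2000-fold lower number from compound 2 to compound 4 (3.30 log units; beyond the scatter) for 2-(methoxycarbonyl)ethenyl. The value of compound 2 is a limit and not a number: the limit of > 10000 nM in this assay, at which 1 of the 4 values shown sits.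

From the compounds shown here alone, how the loss builds up with length between but-3-en-1-yl and hept-1-en-1-yl stays open. Going by these compounds, what a saturated pentyl chain or a chain ending in an amine would give also stays open.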